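Compound 3 after two readings at the limit

The source may report more compounds than this note shows. Statements on the series, on what has been measured and on what is new or still open speak of the compounds shown alone.

Measured so far in a functional assay on OVCAR-3 cells (Homo sapiens) for antiproliferative activity, read by spectrophotometry, with a stated time of 2 days; a lower number here means a stronger inhibitor of growth, a higher number a weaker inhibitor of growth:
Compound 1 `COc1cc(Nc2ncc(C(F)(F)F)c(N3Cc4cccc(N(C)S(C)(=O)=O)c4C3)n2)c(OC)cc1Cl`: > 30000 nM
Compound 2 `Cc1cc(F)ccc1Nc1ncc(C(F)(F)F)c(N2Cc3cccc(N(C)S(C)(=O)=O)c3C2)n1`: > 30000 nM

Compound 2 gives > 30000 nM, and this is a limit of the assay rather than a number. Compound 1 gives > 30000 nM, which is likewise a limit. Among the measured compounds shown here, compound 2 therefore has no measured rank of its own, and the series so far stands at the limit of > 30000 nM in this assay, at which 2 of the 2 values shown sit.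

Compound 3 `Cc1cc(C)cc(Nc2ncc(C(F)(F)F)c(N3Cc4cccc(N(C)S(C)(=O)=O)c4C3)n2)c1` differs from compound 2 in one group: 3,5-dimethylphenyl in place of 4-fluoro-2-methylphenyl on a nitrogen on an aromatic ring. Here 3,5-dimethylphenyl stands in place of 4-fluoro-2-methylphenyl on a nitrogen on an aromatic ring.

For the measured compounds named here, the only measured step at this place is a step that the two limits leave unreadable from compound 1 to compound 2. It offers no size to carry forward, so no step beyond the scatter, in either direction, is expected in this assay. The estimated step is a number no higher from compound 2 to compound 3 (the limit leaves the size open). The assay may well report only a limit again. For compound 3 the estimated value is 30000 nM, with an expected range from 12000 nM to 60000 nM.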

Compound 3, concentration for 50% growth inhibition: > 30000 nM
Compound 3 ended at the assay's limit; the forecaster's own chance of this, stated with the estimate: 80%; the middle value sits exactly at the limit.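

In this assay compound 3 gives > 30000 nM, which is a limit of the assay and not a number. No step among compound 1, compound 2 and compound 3 can be read, and the series stands as follows: the limit of > 30000 nM in this assay, at which 3 of the 3 values shown sit.

The compounds shown leave open whether any group at this place on the nitrogen would give a measurable value.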